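From 2-methylphenyl to 4-methoxyphenyl in a small series

The compounds below may be only part of what the source reports. "The series", "measured", "known", "first", "only" and "open" are said of these compounds alone.

In a functional assay on SGC-7901 cells (Homo sapiens) for inhibition, read by MTT assay, with a stated time of 24 h (on this read-out lower numbers stand for stronger inhibition and higher numbers for weaker inhibition), compound 1 `CC1(C)[C@H]2CC[C@]1(C)N(Cc1cn(-c3ccccc3)nn1)C(=O)C2` gives 240 nM and compound 2 `CC1(C)[C@H]2CC[C@]1(C)N(Cc1cn(-c3ccccc3O)nn1)C(=O)C2` gives 410 nM while compound 3 `Cc1ccccc1-n1cc(CN2C(=O)C[C@@H]3CC[C@@]2(C)C3(C)C)nn1` stands at 350 nM with no distinct place among them, as all three numbers lie within the scatter of one another. Compound 4 `COc1ccc(-n2cc(CN3C(=O)C[C@@H]4CC[C@@]3(C)C4(C)C)nn2)cc1` differs from compound 3 by 4-methoxyphenyl in place of 2-methylphenyl on an aromatic nitrogen. Among the measured compounds shown here, three measured steps bear on this change: a 1.5-fold higher number from compound 1 to compound 3 (0.16 log units; within the scatter) with methyl in place of hydrogen on an aromatic carbon, a 1.7-fold higher number from compound 1 to compound 2 (0.23 log units; within the scatter) with hydroxy in place of hydrogen on an aromatic carbon, and a 1.2-fold lower number from compound 2 to compound 3 (0.07 log units; within the scatter) with methyl in place of hydroxy on an aromatic carbon. For the measured compounds named here, all three stay within the scatter, although no measured compound carries a methoxy group, so no step beyond the scatter is expected in this assay here. The step expected is a 1.2-fold lower number from compound 3 to compound 4 (0.07 log units; within the scatter) and it stays within the scatter. Compound 4 is expected at 300 nM with an estimated range from 130 nM to 700 nM in this measurement.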

Compound 4, half-maximal inhibitory concentration: 480 nM
Compound 4: middle estimate off by 1.6-fold (0.20 log units), on the low side; the measured number falls inside the stated range.
By their numbers in this assay, from the lowest: compounds 1, 3, 2 and 4 (each within the scatter of the next).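

In this assay, among the compounds shown here, 4-methoxyphenyl on the aromatic nitrogen gives a 1.4-fold higher number from compound 3 to compound 4 (0.14 log units; within the scatter), and in place of 2-hydroxyphenyl it gives a 1.2-fold higher number from compound 2 to compound 4 (0.07 log units; within the scatter), so a methoxy group, absent from the earlier compounds, leaves the number within the scatter of both. Against the unsubstituted phenyl of the series, methoxy in place of hydrogen gives a 2.0-fold higher number from compound 1 to compound 4 (0.30 log units; within the scatter), also printed as within the scatter, so all four aryl groups shown on this nitrogen remain indistinguishable in this assay. Nothing given here offers an explanation for these numbers.

The step from compound 3 changes both the group and its place on the phenyl ring, so the two cannot be told apart. On these data alone, whether an amine or a carboxylic acid on that ring would leave a step beyond the scatter also remains open.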